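Shifting fluorine: 2-fluorophenyl to 3-fluorophenyl

The source may hold more compounds than are shown below. What is called first, only, known or untested is meant among the compounds shown, and "the series" means these compounds.

Measured compounds:
compound 1 `O=C(c1cccc(F)c1)N1CCCn2nc(COc3ccccc3)cc21`: 61%
compound 2 `CC(=O)N1CCCn2nc(COc3ccccc3F)cc21`: 60%

Both were tested in a functional assay on HEK293 cells for positive allosteric modulation of metabotropic glutamate receptor 5 (Homo sapiens), read by calcium flux; a higher number here means a larger maximal response, a lower number a smaller maximal response. Of the two numbers, compound 2 has the smaller one, but the gap to compound 1 lies within the usual scatter, so compound 1 and compound 2 cannot be told apart on this evidence.

Compound 3 `CC(=O)N1CCCn2nc(COc3cccc(F)c3)cc21` has not yet been measured. It differs from compound 2 in one place only: 3-fluorophenyl in place of 2-fluorophenyl on an oxygen on a saturated carbon. Among the compounds with values here, nothing measured so far shows how such a change acts in this assay, and the one pair measured, compound 1 and compound 2, differs elsewhere and gives no guidance. Within the data shown here, with no measured step to lean on, the expected change from compound 2 to compound 3 is none beyond the scatter, in either direction, which is the meaning of no change at the digits printed from compound 2 to compound 3 (within the scatter).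

Compound 3 is therefore estimated to give about 60% in this assay, within a range from 45% to 75%.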

Compound 3, largest response reached (reported as percent of maximum), in percent of the reference or control that the assay uses: 58%
Compound 3: the middle estimate sits 2 percentage points above what was measured; the measured number falls inside the stated range.
By their numbers in this assay, from the lowest: compounds 3, 2 and 1 (each within the scatter of the next).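

Within the data shown here, this is the first step that changes one place only, so it gives the first direct reading of this position. With 3-fluorophenyl in place of 2-fluorophenyl on an oxygen on a saturated carbon, this assay gives a number 2 percentage points lower from compound 2 to compound 3 (within the scatter), so these two placements of the fluorine cannot be told apart by this largest response, at least with the acetyl group of compound 2 and compound 3 in place. No supporting measurement here bears on why the two compounds cannot be separated.

A single step cannot show how far this insensitivity extends, since both groups are fluorophenyl rings with the same atoms. A 4-fluorophenyl group, a plain phenyl group on the same acetyl compound, or a phenyl ring carrying a methoxy group or an amine could still behave differently.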